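This account rests on a few compounds, and the source may have more. Where it says the series, first, only, none or still open, it means among the compounds named here.

The measured compounds:
Compound 1 `CC/C=C/C(=O)Nc1cccc(Oc2nc(Nc3ccn(C)n3)nc3c2CSCC3)c1`: in a functional assay on HeLa cells (Homo sapiens) for antiproliferative activity, read by MTT assay, with a stated time of 72 h (a higher number here means a weaker inhibitor, a lower number a stronger inhibitor), compound 1 reaches only > 50000 nM, which is a limit of the assay and not a number.
Compound 2 `CCC/C=C/C(=O)Nc1cccc(Oc2nc(Nc3ccn(C)n3)nc3c2CSCC3)c1`: compound 2 gives 17000 nM in this assay.
Compound 3 `CC/C=C/C(=O)Nc1cccc(Oc2nc(Nc3cccc(C#N)c3)nc3c2CSCC3)c1`: compound 3 gives 31800 nM in this assay.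

Compound 2 differs from compound 1 by methyl in place of hydrogen on a saturated chain carbon, two bonds along the chain from a double-bonded chain carbon, and this change brought an at least 2.9-fold lower number from compound 1 to compound 2 (0.46 log units; beyond the scatter); the step is known only as a floor because of the limit of > 50000 nM in this assay, at which 1 of the 3 values shown sits. The core of compound 3 differs from that of compound 1 by 3-cyanophenyl in place of 1-methyl-1H-pyrazol-3-yl on a nitrogen on an aromatic ring, which gave an at least 1.5-fold lower number from compound 1 to compound 3 (0.19 log units; that floor lies within the scatter). Compound 4 `CCC/C=C/C(=O)Nc1cccc(Oc2nc(Nc3cccc(C#N)c3)nc3c2CSCC3)c1` carries the same change on the core of compound 3, namely (methyl in place of hydrogen on a saturated chain carbon, two bonds along the chain from a double-bonded chain carbon), at the same place. Since compound 1 to compound 2 gave an at least 2.9-fold lower number from compound 1 to compound 2 (0.46 log units; beyond the scatter), compound 4 is expected to show about a 2.9-fold lower number from compound 3 to compound 4 (0.46 log units; beyond the scatter). Compound 4 is thus estimated at 11000 nM, expected to fall between 4000 nM and 30000 nM.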

Compound 4, half-maximal inhibitory concentration: 7220 nM
Compound 4: the middle estimate sits 1.5-fold (0.18 log units) above what was measured; measured number inside the range.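

In this assay the added methyl also lowered the number on the core of compound 3, with a 4.4-fold lower number from compound 3 to compound 4 (0.64 log units; beyond the scatter), so this change carried across the two cores shown: the same change on two cores in this assay, an at least 2.9-fold lower number (0.46 log units; beyond the scatter) from compound 1 to compound 2 and a 4.4-fold lower number (0.64 log units; beyond the scatter) from compound 3 to compound 4; the limit leaves it open whether they differ. The swap to 3-cyanophenyl, read on the pent-1-en-1-yl compounds, gave a 2.4-fold lower number from compound 2 to compound 4 (0.37 log units; beyond the scatter), and it stands beside its earlier counterpart thus: the same change on two cores in this assay, an at least 1.5-fold lower number (0.19 log units; that floor lies within the scatter) from compound 1 to compound 3 and a 2.4-fold lower number (0.37 log units; beyond the scatter) from compound 2 to compound 4; the limit leaves it open whether they differ. Compound 1 gives > 50000 nM, which is a limit of the assay and not a number, so the data do not show whether either change has the same size on both cores.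

On these data alone, it remains open whether a chain longer than pent-1-en-1-yl would lower the number further. As far as these compounds go, it is equally open whether the methyl step would hold with an amine or a carboxylic acid in place of the nitrile, or on any other core.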